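Amide group change: from compound 2 to compound 3

A few compounds are considered here, and "the series" means these few. Any claim that something is new, unique, unknown or untested is made for them only; others in the source may bear on it.

Measured in a functional assay on K562 cells (Homo sapiens) for cytotoxicity, read by MTT assay, with a stated time of 24 h; a lower number here means a stronger inhibitor, a higher number a weaker inhibitor:
- compound 1 `COc1ccc(/C=C\c2cc(OC)c(OC)c(OC)c2)cc1NC(=O)C1=CC(C)(C)N([O])C1(C)C`: > 100000 nM (a limit)
- compound 2 `COc1ccc(/C=C\c2cc(OC)c(OC)c(OC)c2)cc1NC(=O)C1CC(C)(C)N([O])C1(C)C`: 10400 nM

Going by the values given here, compound 2 holds the only actual number, 10400 nM. Compound 1 gives only a limit, > 100000 nM.

Compound 3 `COc1ccc(/C=C\c2cc(OC)c(OC)c(OC)c2)cc1NC(=O)C1=CC(C)(C)N([O])C(C)(C)C1` has not been measured. It differs from compound 2 on a carbonyl carbon: a group of 11 heavy atoms (9 carbon, 1 nitrogen, 1 oxygen; one six-membered non-aromatic ring with 1 hetero atom) in place of a group of 10 heavy atoms (8 carbon, 1 nitrogen, 1 oxygen; one five-membered non-aromatic ring with 1 hetero atom), on a carbonyl carbon. The entering group has a double bond outside aromatic rings. The group of compound 1 has one too, but the group of compound 2 does not.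

Among the compounds with values here, the one measured step that bears on this change is an at least 9.6-fold lower number from compound 1 to compound 2 (0.98 log units; beyond the scatter). Its size rests on a limit, and ring size does not vary between the measured compounds, so it offers only weak guidance. The shared double bond points to a move toward the weaker end in this assay, probably smaller than that measured step. The expected step is a 2.9-fold higher number from compound 2 to compound 3 (0.46 log units; beyond the scatter). Compound 3 is estimated at 30000 nM, with an expected range of 8000 nM to 100000 nM.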

Compound 3, half-maximal inhibitory concentration: 15600 nM
Compound 3: the middle estimate sits 1.9-fold (0.28 log units) above what was measured; low and high end bracket the measured number.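

In this assay, the exchange on the carbonyl carbon gives a 1.5-fold higher number from compound 2 to compound 3 (0.18 log units; within the scatter), so the six-membered group with its double bond and the five-membered group without one cannot be told apart at this position. A double bond outside aromatic rings in this group therefore does not by itself mark the weak end of this assay: with the double bond kept and the ring size changed, the result is an at least 6.4-fold lower number from compound 1 to compound 3 (0.80 log units; beyond the scatter). The size of that step is not exact, and compound 1 stands only as a limit: the limit of > 100000 nM in this assay, at which 1 of the 3 values shown sits.

The compounds shown do not separate ring size from the double bond across the whole set, and a six-membered ring without the double bond would be needed to show what each contributes on this carbonyl carbon. From the compounds shown here alone, it also remains open whether a plain cyclohexyl group, which has no ring nitrogen or oxygen, or an open tert-butyl group would stay near compound 3 at 15600 nM or move clearly away from it.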